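A few compounds are considered here, and "the series" means these few. Any claim that something is new, unique, unknown or untested is made for them only; others in the source may bear on it.

Measured so far in a functional assay on A549 cells (Homo sapiens) for inhibition, read by sulforhodamine B assay, with a stated time of 48 h; a lower number here means a stronger inhibitor of growth, a higher number a weaker inhibitor of growth:
compound 1, `COC(=O)[C@@]1(C)CCC=C2[C@@H]1CC[C@@H](C)[C@]2(C)Cc1c[nH]c2ccc(OC)cc12`, gives 2200 nM;
compound 2, `COC(=O)[C@@]1(C)CCC=C2[C@@H]1CC[C@@H](C)[C@]2(C)Cc1c(C)[nH]c2ccccc12`, gives 15000 nM;
compound 3, `COC(=O)[C@@]1(C)CCC=C2[C@@H]1CC[C@@H](C)[C@]2(C)Cc1c(C)[nH]c2ccc(OC)cc12`, gives 16000 nM.

Compound 1 and compound 3 share a core and differ by one change: methyl in place of hydrogen on an aromatic carbon. That change carried a 7.3-fold higher number from compound 1 to compound 3 (0.86 log units; beyond the scatter). Compound 2 and compound 3 likewise differ in one place, a methoxy in place of hydrogen on an aromatic carbon, which gave a 1.1-fold higher number from compound 2 to compound 3 (0.03 log units; within the scatter). The difference between the cores of compound 1 and compound 2 is not broken down here.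

Compound 4, `COC(=O)[C@@]1(C)CCC=C2[C@@H]1CC[C@@H](C)[C@]2(C)Cc1c(C)[nH]c2c(C)cccc12`, is not yet measured. It differs from compound 2 by methyl in place of hydrogen on an aromatic carbon. This is the same kind of change as that from compound 1 to compound 3, not the same: there the methyl entered on a five-membered aromatic ring with 1 nitrogen, next to the ring nitrogen and next to the ring atom that bears a large group; here it enters on a six-membered aromatic ring of carbon only, ortho to a fused ring and meta to a fused ring.

Within the data shown here, because compound 2 stands at 15000 nM and the only precedent for a methyl entering, from compound 1 to compound 3, sits at a different place, the expected step is a small one, a 1.2-fold higher number from compound 2 to compound 4 (0.08 log units; within the scatter). Compound 4 is estimated at 18000 nM in this assay, with a range from 7000 nM to 45000 nM.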

Compound 4, concentration for 50% growth inhibition: 14000 nM
Compound 4: the middle estimate sits 1.3-fold (0.11 log units) above what was measured, and the stated range covers the measured number.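

In this assay, a methyl in place of hydrogen on an aromatic carbon does not carry from one core to another as a fixed step, and the two steps shown differ: the same change on two cores in this assay, a 7.3-fold higher number (0.86 log units; beyond the scatter) from compound 1 to compound 3 and a 1.1-fold lower number (0.03 log units; within the scatter) from compound 2 to compound 4, 7.8-fold (0.89 log units) apart, beyond the scatter of two such steps. On a six-membered aromatic ring of carbon only, ortho to a fused ring and meta to a fused ring, the methyl gave a 1.1-fold lower number from compound 2 to compound 4 (0.03 log units; within the scatter). This does not show whether the core or the place of the methyl sets the gap, since the two steps differ in both, and it gives no cause for the gap.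

Open, as far as these compounds go, is what the same methyl on the six-membered ring would do on the core of compound 1, the one core here where a methyl entering gave a step beyond the scatter. Also open, from the compounds shown here alone, is whether a chlorine, an amine or a carboxylic acid at that carbon would behave as the methyl does.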